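From pyridin-3-yl to 3,4-dihydroxyphenyl

The compounds below may be only part of what the source reports. "The series", "measured", "known", "first", "only" and "open" are said of these compounds alone.

Among the measured compounds shown here, in a functional assay for inhibition, with Homo sapiens as the target (a lower number here means a stronger inhibitor, a higher number a weaker inhibitor), compound 1 `O=C1CCc2cc(-c3csc(-c4cccnc4)n3)ccc2N1` gives 1000 nM, the lower of the two numbers measured so far, which makes it the stronger inhibitor of the pair. Compound 2 `COc1ccc(Cc2nc(-c3ccc4c(c3)CCC(=O)N4)cs2)cc1OC` gives 10000 nM, a gap well beyond the usual scatter. Compound 3 `O=C1CCc2cc(-c3csc(-c4ccc(O)c(O)c4)n3)ccc2N1` has not been measured yet. It keeps the core of compound 1 and changes a single group: 3,4-dihydroxyphenyl in place of pyridin-3-yl on an aromatic carbon. For the measured compounds named here, no measured pair of compounds shows a change like this one, so there is little to guide the size of the step. A small weakening is expected, with the estimated step being a 2.0-fold higher number from compound 1 to compound 3 (0.30 log units; within the scatter), and it may hardly leave the scatter. The expected value for compound 3 is 2000 nM, with an estimated range from 300 nM to 10000 nM.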

Compound 3, half-maximal inhibitory concentration: 1000 nM
Compound 3: middle estimate off by 2.0-fold (0.30 log units), on the high side, within the range that was stated.
By their numbers in this assay, from the lowest: compounds 1 and 3 (each within the scatter of the next); then compound 2.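

In this assay, among the compounds shown here, the move to 3,4-dihydroxyphenyl in place of pyridin-3-yl gives no change at the digits printed from compound 1 to compound 3 (within the scatter) and so offers the first direct reading at this position, on an aromatic carbon of the five-membered ring with nitrogen and sulfur. The position accepts a ring of carbon only, bearing hydrogen-bond donors that pyridin-3-yl lacks, in place of a ring with a hetero atom, with no loss of inhibition beyond the scatter. Nothing measured on these compounds explains why the two groups read alike.

Whether both hydroxyl groups are needed for this reading stays open, since a single hydroxyl on the phenyl ring is not among the compounds shown. It is also unknown how a phenyl ring carrying an amine or a carboxylic acid would read at this position.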